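From dimethylamino to butylsulfanyl on a shared core

The source may report more compounds than this note shows. Statements on the series, on what has been measured and on what is new or still open speak of the compounds shown alone.

Compound 1 `CNc1nc(N)nc2c1ncn2/C=C1/CC1(CO)CO` gives > 20000 nM in an ADME assay on CCRF-HSB-2 cells (Homo sapiens) for cytotoxicity, with a stated time of 7 days (on this read-out higher numbers stand for lower toxicity in this test and lower numbers for higher toxicity in this test), a limit of the assay rather than a number.
Compound 2 `CN(C)c1nc(N)nc2c1ncn2/C=C1/CC1(CO)CO` gives > 20000 nM, again a limit.
Compound 3 `CCCCCCSc1nc(N)nc2c1ncn2/C=C1/CC1(CO)CO` gives 60000 nM.

Compound 2 therefore stands at a limit, and among the values shown (the limit of > 20000 nM in this assay, at which 2 of the 3 values shown sit), so no order among the three can be read. The unmeasured compound 4 `CCCCSc1nc(N)nc2c1ncn2/C=C1/CC1(CO)CO` differs from compound 2 in one place: butylsulfanyl in place of dimethylamino on an aromatic carbon. Within the data shown here, three measured steps touch this change, but none gives a size: a step that the two limits leave unreadable from compound 1 to compound 2, a step that the limit leaves unreadable from compound 1 to compound 3 and a step that the limit leaves unreadable from compound 2 to compound 3 all stay hidden behind the limits. No step size can thus be derived, and no direction either. Among the measured compounds shown here, the only number is that of compound 3, which carries hexylsulfanyl, a chain of the same kind as butylsulfanyl. Compound 4 is expected to land near it, at 50000 nM, with a range from 20000 nM to 150000 nM, because compound 3 gives 60000 nM. The step that the limit leaves unreadable from compound 2 to compound 4 is an estimate only, since compound 2 itself is a limit.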

Compound 4, half-maximal cytotoxic concentration: 89000 nM
Beside the measured number, compound 4's estimate is 1.8-fold (0.25 log units) below it; the range from low to high includes it.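

Among these compounds, with compound 4, a second sulfanyl chain on this aromatic carbon has a measured number in this assay, which makes possible the first readable step: a 1.5-fold higher number from compound 3 to compound 4 (0.17 log units; within the scatter). Hexylsulfanyl and butylsulfanyl therefore cannot be told apart at this position, as this difference in chain length stays within the usual scatter of the read-out. The steps from compound 1 and compound 2 to compound 4 cannot be read, since those two compounds stand at a limit of the assay and not at a number: the limit of > 20000 nM in this assay, at which 2 of the 4 values shown sit.

Going by these compounds, whether a much shorter chain, such as methylsulfanyl, would fall in the same range stays open. A butylamino group, with the same chain on nitrogen instead of sulfur, would be needed to separate the role of the sulfur from that of the chain.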